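Swapping the aryl group on the amide carbonyl

The source may report more compounds than this note shows. Statements on the series, on what has been measured and on what is new or still open speak of the compounds shown alone.

Two compounds share a core in which a dodecyl chain sits on a tetrazole ring; they differ only in the aryl group on the amide carbonyl. Compound 1 `CCCCCCCCCCCCn1nnc(C(NC(=O)c2c(C)cccc2C)c2ccccc2)n1` gives 310 nM in an assay on microsomes from liver for inhibition of sterol O-acyltransferase 1 (Rattus norvegicus); on this read-out higher numbers stand for weaker inhibition and lower numbers for stronger inhibition. Compound 2 `CCCCCCCCCCCCn1nnc(C(NC(=O)c2ccc(F)cc2F)c2ccccc2)n1` gives 490 nM in this assay; the step of a 1.6-fold higher number from compound 1 to compound 2 (0.20 log units; within the scatter) lies within the scatter, so compound 2 and compound 1 are indistinguishable on these numbers. Compound 3 `CCCCCCCCCCCCn1nnc(C(NC(=O)c2ccc(Cl)cc2)c2ccccc2)n1` carries the change (4-chlorophenyl in place of 2,4-difluorophenyl on a carbonyl carbon). For the measured compounds named here, the only measured step that bears on such a change is the aryl swap a 1.6-fold higher number from compound 1 to compound 2 (0.20 log units; within the scatter), which was itself within the scatter. It is therefore expected that the step of a 1.2-fold lower number from compound 2 to compound 3 (0.09 log units; within the scatter) stays within the scatter as well. Compound 3 is estimated to give about 400 nM in this assay, with a range from 150 nM to 1200 nM.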

Compound 3, half-maximal inhibitory concentration: 440 nM
For compound 3 the middle estimate is 1.1-fold (0.04 log units) below the measured one; low and high end bracket the measured number.
By their numbers in this assay, from the lowest: compounds 1, 3 and 2 (each within the scatter of the next).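

A third aryl group on the amide carbonyl now fits the same picture: the change to 4-chlorophenyl gives a 1.1-fold lower number from compound 2 to compound 3 (0.05 log units; within the scatter) and, set against the 2,6-dimethylphenyl group, a 1.4-fold higher number from compound 1 to compound 3 (0.15 log units; within the scatter) in this assay. Three aryl groups carrying methyl, fluorine or chlorine at different ring positions therefore cannot be told apart on these numbers, so this position on a carbonyl carbon has accepted each of them with no change beyond the scatter. No evidence is available on what lies behind this flat result.

As far as these compounds go, whether an aryl ring bearing a carboxylic acid or an amine would stay within the scatter remains open. From the compounds shown here alone, all three compounds also share the dodecyl chain, so it is equally open whether these aryl swaps would read the same with a shorter chain.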